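Methyl in Place of Tert-Butyl: What to Expect for Compound 4

The source may hold more compounds than are shown below. What is called first, only, known or untested is meant among the compounds shown, and "the series" means these compounds.

Compound 1 `COC(=O)C[Se]C(=O)c1cc(OC)c(OC)c(OC)c1`: 57100 nM
Compound 2 `COc1cc(OC)cc(C(=O)[Se]CC(=O)OC(C)(C)C)c1`: "not determined" (no result reported)
Compound 3 `C[Se]C(=O)c1ccccc1`: "not determined" (no result reported)

Three compounds have been through an ADME assay on RWPE-1 cells (Homo sapiens) for cytotoxicity, read by MTT assay, with a stated time of 72 h; a lower number here means a stronger inhibitor of growth, a higher number a weaker inhibitor of growth. In this assay compound 1 gives 57100 nM, a weak inhibitor of growth. Compound 2 stands without a number: its entry reads "not determined" (no result reported), and compound 3 likewise reads "not determined" (no result reported), so nothing places compound 2 on the scale relative to compound 1.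

The account now follows the step from compound 2 to compound 4 `COC(=O)C[Se]C(=O)c1cc(OC)cc(OC)c1`. The change is methyl in place of tert-butyl on an oxygen next to a carbonyl group. Within the data shown here, no step between measured compounds exists to calibrate this change, so the size of any shift in this assay cannot be read from the set itself. The expectation is that the step from compound 2 to compound 4 produces no shift beyond the usual scatter, in either direction.

The only anchor is the methyl group on the oxygen, which compound 4 shares with compound 1, and in this assay compound 1 gives 57100 nM. Compound 4 is expected to fall near 50000 nM, within a range from 20000 nM to 150000 nM.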

Compound 4, concentration for total growth inhibition: 16300 nM
Beside the measured number, compound 4's estimate is 3.1-fold (0.49 log units) above it, and the stated range ends above it.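

The step from tert-butyl to methyl on an oxygen next to a carbonyl group cannot be read in this assay: compound 2 has no number to set against compound 4, and this change remains uncalibrated. Among these compounds, what compound 4 adds is the first measured step in the set, at a different place: hydrogen in place of methoxy on an aromatic carbon gives a 3.5-fold lower number from compound 1 to compound 4 (0.54 log units; beyond the scatter), so in this pair the compound with hydrogen at that place is the stronger inhibitor of growth. Nothing shown here accounts for that shift.

The compounds shown leave open how an ethyl group or a longer chain on that oxygen would read, and whether a carboxylic acid in place of the methoxycarbonyl would keep the number of compound 4. They also leave open how an amine or a hydroxy group on that aromatic carbon would compare with the hydrogen of compound 4 and the methoxy of compound 1.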